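Dimethylamino for Phenoxy on the Cytotoxic Pyrazole Series

The source may report more compounds than this note shows. Statements on the series, on what has been measured and on what is new or still open speak of the compounds shown alone.

Of the compounds shown here, two have so far been measured in a functional assay on NCI-H522 cells (Homo sapiens) for cytotoxicity, read by sulforhodamine B assay, with a stated time of 48 h, tested at 10 uM; a higher number here means a weaker effect of the compound at the concentration tested, a lower number a stronger effect. Compound 1 `COc1cc(C)cc(-c2nn(CC#N)cc2-c2ccc(-c3cccc(C(C)=O)c3)nc2)c1` gives -40%, while compound 2 `Cc1cc(O)cc(-c2nn(CC#N)cc2-c2ccnc(-c3ccc(Oc4ccccc4)cc3)c2)c1` gives -93%, the lowest of the two numbers and beyond the scatter from compound 1. Compound 3 `Cc1cc(O)cc(-c2nn(CC#N)cc2-c2ccnc(-c3ccc(N(C)C)cc3)c2)c1` remains unmeasured; it differs from compound 2 by dimethylamino in place of phenoxy on an aromatic carbon. Going by the values given here, no comparable step between measured compounds exists, so the size of the change is open, but a moderate move toward a weaker effect in this assay is expected, likely beyond the scatter. For compound 3 an activity of -65% is estimated, within -95% to -15%. This estimate implies an expected step of a number 28 percentage points higher from compound 2 to compound 3 (beyond the scatter).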

Compound 3, a percentage reported as activity, at one concentration (the size of the read-out at that concentration, not a potency): -57%
Compound 3: the middle estimate sits 8 percentage points below what was measured; low and high end bracket the measured number.
By their numbers in this assay, from the lowest: compound 2; then compound 3; then compound 1.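

Going by these compounds alone, replacing phenoxy with dimethylamino on this aromatic carbon gives, in this assay, a number 36 percentage points higher from compound 2 to compound 3 (beyond the scatter), the first single-place comparison, and it shows that the read-out depends on the group at this position. The exchange removes a six-membered aromatic ring of carbon only, yet compound 3 still gives -57% in this assay. No available evidence accounts for the step.

As far as these compounds go, whether the ring itself or the oxygen link matters remains open, since neither anilino nor methoxy appears at this position. A morpholine at this carbon is equally untested among the compounds shown.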